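The compounds below may be only part of what the source reports. "The series", "measured", "known", "first", "only" and "open" are said of these compounds alone.

Three related compounds frame this question, and only one of them supplies a number. In a functional assay on MCF7 cells (Homo sapiens) for cytotoxicity, read by MTT assay, with a stated time of 72 h (on this read-out higher numbers stand for weaker inhibition and lower numbers for stronger inhibition), compound 1 `O=C(NCc1ccc(F)cc1)c1nc(NCCO)c2cccnc2c1O` gives "not determined" (no result reported). Compound 2 `Nc1ccc(Nc2c(C(=O)NCc3ccc(F)cc3)nc(Br)c3cccnc23)cc1` gives 4000 nM, the only numerical result in the set. Compound 3 `COc1cccc(CNC(=O)c2nc(Br)c3cccnc3c2N[C@H]2CC[C@H](N)CC2)c1` gives "not determined" (no result reported), so it has no single number to stand on, and compound 1 is in the same position.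

Compound 4 `CN(C)c1ccc(CNC(=O)c2nc(Br)c3cccnc3c2N[C@H]2CC[C@H](N)CC2)cc1` departs from compound 3 in one place: 4-(dimethylamino)phenyl in place of 3-methoxyphenyl on a saturated chain carbon bound to an amide-type nitrogen. In other words, 4-(dimethylamino)phenyl takes the place of 3-methoxyphenyl on a saturated chain carbon bound to an amide-type nitrogen, so that 3-methoxybenzyl becomes 4-(dimethylamino)benzyl.

Within the data shown here, no pair of measured compounds differing in one place is available, and compound 3 offers no starting value, so the data do not show what such a change does. In this assay, no step beyond the scatter is expected, and no direction is favoured. The expectation therefore rests on compound 2 at 4000 nM, the sole anchor, and the range is kept wide since compound 2 differs from compound 3 in more than one place. For compound 4, the expected value is 3000 nM, with an estimated range from 600 nM to 15000 nM.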

Compound 4, half-maximal inhibitory concentration: 5000 nM
Compound 4: middle estimate off by 1.7-fold (0.22 log units), on the low side, and the stated range covers the measured number.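

In this assay, among these compounds, compound 3 gives "not determined" (no result reported) while compound 4 gives 5000 nM and no step between the two can be read. What the change from 3-methoxybenzyl to 4-(dimethylamino)benzyl does to this read-out stays open in the compounds shown. Nothing shown here offers an explanation for the value of compound 4.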